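The source may hold more compounds than are shown below. What is called first, only, known or untested is meant among the compounds shown, and "the series" means these compounds.

The three measured compounds share one core and differ only in the aryl group on the hydrazone nitrogen. Compound 1 `CC1CC/C(=N\Nc2ccc(F)cc2)c2ncc(C(=O)O)c(=O)n21` gives 12.2 umol/kg in a functional assay on the whole organism for inhibition, with Rattus norvegicus as the target; a lower number here means that less compound is needed, a higher number that more compound is needed for the effect. Compound 2 `CC1CC/C(=N\Nc2ccc(Br)cc2)c2ncc(C(=O)O)c(=O)n21` gives 0.8 umol/kg, and compound 3 `CC1CC/C(=N\Nc2ccccc2O)c2ncc(C(=O)O)c(=O)n21` gives 0.26 umol/kg, the lowest of the three numbers, with compound 2 nearest to it and compound 1 furthest from it. The three steps are a 15-fold lower number from compound 1 to compound 2 (1.18 log units; beyond the scatter), a 47-fold lower number from compound 1 to compound 3 (1.67 log units; beyond the scatter) and a 3.1-fold lower number from compound 2 to compound 3 (0.49 log units; beyond the scatter).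

Compound 4 `CC1CC/C(=N\Nc2ccc(O)cc2)c2ncc(C(=O)O)c(=O)n21` differs from compound 3 in that (4-hydroxyphenyl in place of 2-hydroxyphenyl on an amine nitrogen). Going by the values given here, no measured step moves a hydroxyl from one ring position to another. The two steps that bear on the change, a 47-fold lower number from compound 1 to compound 3 (1.67 log units; beyond the scatter) and a 3.1-fold lower number from compound 2 to compound 3 (0.49 log units; beyond the scatter), both show 2-hydroxyphenyl giving a lower number than a 4-substituted phenyl, so part of the standing of compound 3 may rest on the 2-hydroxyphenyl itself. A rise of modest size is therefore expected, with the expected step being a 3.1-fold higher number from compound 3 to compound 4 (0.49 log units; beyond the scatter). Compound 4 is estimated at 0.8 umol/kg, with a range from 0.2 umol/kg to 3.5 umol/kg.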

Compound 4, dose for 50% inhibition: 1.7 umol/kg
Compound 4: the middle estimate sits 2.1-fold (0.33 log units) below what was measured, within the range that was stated.
By their numbers in this assay, from the lowest: compound 3; then compound 2; then compound 4; then compound 1.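

In this assay, the ring position of the hydroxyl matters, and not only its presence: the 2-hydroxyphenyl and 4-hydroxyphenyl groups have the same atoms, yet the move gives a 6.5-fold higher number from compound 3 to compound 4 (0.82 log units; beyond the scatter). Among the 4-substituted phenyl groups, the order of the numbers is not set by the hydroxy group alone, since hydroxy in place of bromo gives a 2.1-fold higher number from compound 2 to compound 4 (0.33 log units; beyond the scatter), while hydroxy in place of fluoro gives a 7.2-fold lower number from compound 1 to compound 4 (0.86 log units; beyond the scatter). Nothing available explains these differences.

The compounds shown leave open whether the low number of compound 3 depends on the hydroxyl itself or would hold with a methoxy group or an amine in its place. They also leave open where a chloro group on the aromatic carbon would fall relative to the fluoro and bromo groups.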